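The compounds below may be only part of what the source reports. "The series", "measured", "known", "first", "only" and "open" are said of these compounds alone.

Measured so far:
compound 1 `O=C(CCCCC1CCCCC1)OCC1COCCOCCOCCOCCOCCO1` — 51000 nM
compound 2 `CC(C)=CC1C(C(=O)OCC2COCCOCCOCCOCCOCCO2)C1(C)C` — 54000 nM

Going by the values given here, in a functional assay on SW1573 cells (Homo sapiens) for inhibition, read by sulforhodamine B assay, with a stated time of 48 h (a lower number here means a stronger inhibitor of growth, a higher number a weaker inhibitor of growth), compound 2 holds the higher of the two numbers, and compound 1 is its only neighbour; the single step of a 1.1-fold higher number from compound 1 to compound 2 (0.02 log units; within the scatter) stays within the scatter. Compound 3 `CC/C=C/CC(=O)OCC1COCCOCCOCCOCCOCCO1` differs from compound 2 by pent-2-en-1-yl in place of 2,2-dimethyl-3-(2-methylprop-1-en-1-yl)cyclopropyl on a carbonyl carbon. Among the compounds with values here, no measured step replaces this ring with an open chain; the one step known, a 1.1-fold higher number from compound 1 to compound 2 (0.02 log units; within the scatter), exchanged one ester tail for another without effect beyond the scatter. The expected step is therefore a 1.2-fold higher number from compound 2 to compound 3 (0.08 log units; within the scatter), no larger than the scatter, with no firm direction. Compound 3 is estimated at 65000 nM, range 30000 nM to 150000 nM.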

Compound 3, concentration for 50% growth inhibition: > 100000 nM
Compound 3: only a limit was reported; the forecaster's own chance of this, stated with the estimate: 25%; at least 1.5-fold (0.18 log units) between middle value and limit.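

Compound 3 gives only a limit in this assay, not a number: the limit of > 100000 nM in this assay, at which 1 of the 3 values shown sits. The steps read an at least 1.8-fold higher number from compound 2 to compound 3 (0.26 log units; that floor lies within the scatter) and an at least 1.9-fold higher number from compound 1 to compound 3 (0.29 log units; that floor lies within the scatter); both floors lie within the scatter, so neither step is shown to exceed it. Pent-2-en-1-yl, with no ring, is nevertheless the first tail here whose true value may lie beyond the scatter from the others, which the ring-bearing pair did not show.

The compounds shown do not separate the absence of a ring from the smaller tail. As far as these compounds go, how a longer open chain or a tail ending in an amine would read stays open.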